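A few compounds are considered here, and "the series" means these few. Any claim that something is new, unique, unknown or untested is made for them only; others in the source may bear on it.

Compound 1 `O=C(O)c1ccc(C(=O)/C(=C\c2ccc(Cl)c([N+](=O)[O-])c2)SCc2ccc(F)cc2)cc1`: 1000 nM
Compound 2 `O=C(O)c1ccc(C(=O)/C(=C\c2ccc(Cl)c([N+](=O)[O-])c2)SCc2ccccc2F)cc1`: 1000 nM

Within the data shown here, in a functional assay on DU-145 cells (Homo sapiens) for inhibition, read by trypan blue exclusion, with a stated time of 96 h (on this read-out lower numbers stand for stronger inhibition of growth and higher numbers for weaker inhibition of growth), compound 2 gives 1000 nM and stands level with compound 1, the only other compound measured. Compound 3 `O=C(O)c1ccc(C(=O)/C(=C\c2ccc(Cl)c([N+](=O)[O-])c2)S(=O)(=O)Cc2ccc(Br)cc2)cc1` carries (4-bromobenzyl)sulfonyl in place of (2-fluorobenzyl)sulfanyl on a double-bonded chain carbon bound to a carbonyl carbon and a double-bonded chain carbon. Among the measured compounds shown here, only one measured step bears on this change, and only on the benzyl part: no change at the digits printed from compound 1 to compound 2 (within the scatter), for 2-fluorophenyl in place of 4-fluorophenyl. For the measured compounds named here, no measured compound carries a sulfonyl group or a bromine, so the data give no direction for the change at sulfur. The expected step is therefore no change at the digits printed from compound 2 to compound 3 (within the scatter), with wide uncertainty in either direction. For compound 3 the estimated value in this assay is 1000 nM, within an expected range of 250 nM to 4000 nM.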

Compound 3, concentration for 50% growth inhibition in the DU-145 assay: 25000 nM
For compound 3 the middle estimate is 25-fold (1.40 log units) below the measured one; the measured number lies above the stated range.
By their numbers in the DU-145 assay, from the lowest: compounds 1 and 2 (each within the scatter of the next); then compound 3.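

Among these compounds, in the DU-145 assay, (4-bromobenzyl)sulfonyl on this double-bonded chain carbon brings the first change beyond the scatter: a 25-fold higher number from compound 2 to compound 3 (1.40 log units; beyond the scatter), and a 25-fold higher number from compound 1 to compound 3 (1.40 log units; beyond the scatter). The position therefore responds strongly to this change, although moving the fluorine on the benzyl ring gave no change at the digits printed from compound 1 to compound 2 (within the scatter), and nothing in the data bears on why the number rises. In a physicochemical assay for solubility (a lower number here means a less soluble compound, a higher number a more soluble compound), compound 2 gives < 1000 ug/mL, which is a limit of the assay. In the physicochemical assay compound 3 gives < 1000 ug/mL, which is also a limit of the assay. The step in the physicochemical assay cannot be read: the limit of < 1000 ug/mL in the physicochemical assay, at which 2 of the 2 values shown sit.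

The change alters the sulfur and the ring halogen together, so the compounds shown do not tell how much of the step belongs to the sulfonyl group and how much to the bromine. On these data alone, a (4-fluorobenzyl)sulfonyl or (4-bromobenzyl)sulfanyl group would separate the two, and how an amine or a longer chain would fare at this place also remains open.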